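Hydroxycyclopentyl thioether in place of methyl thioether

The source may report more compounds than this note shows. Statements on the series, on what has been measured and on what is new or still open speak of the compounds shown alone.

Compound 1 `CSc1nc(NCc2ccc(-c3ccccn3)cc2)c2[nH]nc(C(C)C)c2n1` is the reference point of this set. In a functional assay on HT cells (Homo sapiens) for antiproliferative activity, read by fluorescence, with a stated time of 72 h (on this read-out lower numbers stand for stronger inhibition of growth and higher numbers for weaker inhibition of growth), compound 1 gives 783 nM, the highest of the three numbers measured, although compound 3 lies within the scatter of it. Compound 2 `CC(C)c1n[nH]c2c(NCc3ccc(-c4ccccn4)cc3)nc(SC[C@H](O)CN)nc12` gives 63 nM and compound 3 `CC(C)c1n[nH]c2c(NCc3ccc(-c4ccccn4)cc3)nc(SCC(C)(C)O)nc12` gives 507 nM. The step of a 12-fold lower number from compound 1 to compound 2 (1.09 log units; beyond the scatter) is large, the step of a 1.5-fold lower number from compound 1 to compound 3 (0.19 log units; within the scatter) stays within the scatter, and between the two larger thioethers the step is an 8.0-fold higher number from compound 2 to compound 3 (0.91 log units; beyond the scatter).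

Compound 4 `CC(C)c1n[nH]c2c(NCc3ccc(-c4ccccn4)cc3)nc(SC3CCCC3O)nc12` differs from compound 1 in one place: 2-hydroxycyclopentyl in place of methyl on a sulfur. Among the measured compounds shown here, the change brings in a hydroxyl group but no amino group, so of the two measured steps it resembles the one to compound 3 rather than the one to compound 2. The large lowering a 12-fold lower number from compound 1 to compound 2 (1.09 log units; beyond the scatter) came with the 2-amino-1-hydroxyethyl group, whereas the hydroxyl-only step a 1.5-fold lower number from compound 1 to compound 3 (0.19 log units; within the scatter) stayed within the scatter. For compound 4 a small step, a 1.7-fold lower number from compound 1 to compound 4 (0.24 log units; within the scatter), is therefore expected, not clearly beyond the scatter. Compound 4 is estimated at 450 nM, with a range from 200 nM to 1000 nM.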

Compound 4, concentration for 50% growth inhibition: 567 nM
Estimate against measurement, compound 4: 1.3-fold (0.10 log units) below; low and high end bracket the measured number.
By their numbers in this assay, from the lowest: compound 2; then compounds 3, 4 and 1 (each within the scatter of the next).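

In this assay a five-membered carbon ring on the sulfur makes no reading difference: 2-hydroxycyclopentyl lies within the scatter of methyl (a 1.4-fold lower number from compound 1 to compound 4 (0.14 log units; within the scatter)) and of 2-hydroxy-2-methylpropyl (a 1.1-fold higher number from compound 3 to compound 4 (0.05 log units; within the scatter)). The 3-amino-2-hydroxypropyl group stays apart (a 9.0-fold higher number from compound 2 to compound 4 (0.95 log units; beyond the scatter)), so among these four thioethers the steps beyond the scatter all involve compound 2, the only one carrying an amino group, while the hydroxyl groups of compound 3 and compound 4 alone bring no shift beyond the scatter. No accompanying data bear on the reason for this difference.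

Open, as far as these compounds go, is whether a 2-aminocyclopentyl group on the sulfur would read like compound 2 or like compound 4. Also open, from the compounds shown here alone, is whether a 3-aminopropyl chain, with the amine but no hydroxyl, would keep the lower number of compound 2.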